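The source may report more compounds than this note shows. Statements on the series, on what has been measured and on what is new or still open speak of the compounds shown alone.

Of the compounds shown here, three built on a shared core have been measured in an assay on isolated protein for inhibition of leukotriene B4 receptor 1 (Homo sapiens), tested at 10 uM; on this read-out higher numbers stand for more inhibition at the one concentration tested (going by the name of the read-out) and lower numbers for less inhibition. Compound 1 `C=CCc1cc(C(C)=O)c(O)cc1OCCCCCCC#N` gives 97%, compound 3 `CCc1cc(C(C)=O)c(O)cc1OCCCCCC(C)(C)c1nnnn1C` gives 99%, and compound 2 `C=CCc1cc(C(C)=O)c(O)cc1OCCCCCCCCCCC#N` gives 50%. Compound 2 thus stands lowest of the three; its nearest neighbour is compound 1, and compound 3 lies furthest from it. Among the measured compounds shown here, the one step between compounds that differ in a single place runs a number 47 percentage points lower from compound 1 to compound 2 (beyond the scatter), a large drop that goes with lengthening the chain that ends in the nitrile.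

Compound 4 `C=CCc1cc(C(C)=O)c(O)cc1OCCCCO` differs from compound 2 in one place: hydroxy in place of 6-cyanohexyl on a saturated chain carbon, four bonds along the chain from an oxygen on an aromatic ring. The long chain ending in the nitrile is thus replaced by a hydroxy group on a far shorter chain. For the measured compounds named here, only the step from compound 1 to compound 2 bears on this, and only loosely: it shows that adding 4-cyanobutyl lowered the number sharply, so taking chain away again may recover much of it. Going by the values given here, no measured compound carries a hydroxy group at this place, so the size of any recovery is uncertain.

Compound 4 is therefore expected to come in higher than compound 2, by an estimated a number 30 percentage points higher from compound 2 to compound 4 (beyond the scatter), at 80% with a range from 55% to 97%.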

Compound 4, a percentage reported as inhibition, at one concentration (the size of the read-out at that concentration, not a potency): 48%
Estimate against measurement, compound 4: 32 percentage points above; measured number below the stated range.
By their numbers in this assay, from the lowest: compounds 4 and 2 (each within the scatter of the next); then compounds 1 and 3 (each within the scatter of the next).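

Replacing 6-cyanohexyl with hydroxy gives a number 2 percentage points lower from compound 2 to compound 4 (within the scatter), so compound 2 and compound 4 cannot be told apart here, even though the change removes a long nitrile-ending chain and leaves a much shorter chain ending in hydroxy. Replacing 2-cyanoethyl with hydroxy gives a number 49 percentage points lower from compound 1 to compound 4 (beyond the scatter), a large step showing that moving away from the chain of compound 1 can cost about as much in the shorter direction as in the longer one, although compound 4 changes the chain end as well as the chain length. No available evidence explains why these two quite different structures give such similar numbers.

The compounds shown do not separate the effect of chain length from that of the end group, which a nitrile in place of the hydroxy on the chain of compound 4 would help to do. They also leave open how an amine or a carboxylic acid at the end of this chain would read, and whether any chain length in the range around compound 1 holds its high number.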